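A few compounds are considered here, and "the series" means these few. Any claim that something is new, unique, unknown or untested is made for them only; others in the source may bear on it.

Measured compounds:
- compound 1 `O=C(CSc1nc2c(c(=O)n1-c1ccccc1)SCC2)Nc1ccc(-c2ccncc2)cc1`: 3 nM
- compound 2 `O=C(CSc1nc2c(c(=O)n1-c1ccccc1)SCC2)Nc1nc(-c2ccccc2)cs1`: 350 nM
- compound 3 `COc1ccc2nc(NC(=O)CSc3nc4c(c(=O)n3-c3ccccc3)SCC4)sc2c1`: 40 nM

All three share the same core and differ in the amide-linked aryl group. In an assay on L cells for inhibition of Protein-serine O-palmitoleoyltransferase porcupine (Mus musculus), read by reporter gene assay, with a stated time of 24 h (on this read-out higher numbers stand for an effect only at larger amounts of compound and lower numbers for an effect already at smaller amounts), compound 1 gives 3 nM, the lowest number of the three. Compound 3 stands nearest to it, and its value of 40 nM lies beyond the scatter; compound 2, with 350 nM, lies furthest away, also beyond the scatter. Compound 1 is thus the most potent of the measured set.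

Compound 4 `O=C(CSc1nc2c(c(=O)n1-c1ccccc1)SCC2)Nc1ccc(-c2ccccc2)cc1` is not yet measured. It differs from compound 1 in one place: phenyl in place of pyridin-4-yl on an aromatic carbon, para to a large group. Going by the values given here, no measured pair in the set isolates this change, so the direction must be judged from the structures alone. The hetero atom and the hydrogen-bond acceptor of the pyridin-4-yl are lost; the ring size and shape are kept. A small to moderate loss is expected, possibly no more than the scatter, and a gain beyond the scatter is not expected.

The expected step from compound 1 to compound 4 in this assay is a 3.3-fold higher number from compound 1 to compound 4 (0.52 log units; beyond the scatter). Compound 4 is estimated at 10 nM in this assay, within a range from 2 nM to 50 nM.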

Compound 4, half-maximal effective concentration: 0.75 nM
Compound 4: the middle estimate sits 13-fold (1.12 log units) above what was measured; measured number below the stated range.
By their numbers in this assay, from the lowest: compound 4; then compound 1; then compound 3; then compound 2.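

In this assay, phenyl in place of pyridin-4-yl on an aromatic carbon, para to a large group, gives a 4.0-fold lower number from compound 1 to compound 4 (0.60 log units; beyond the scatter), a modest step but one beyond the scatter. This is the only pair shown that isolates a single change, and it shows that the hetero atom and hydrogen-bond acceptor of the pyridin-4-yl are not required here for a low number, since the ring of carbon only, with the same count of heavy atoms, gives the lower number. Nothing available explains the step, so it stands as an observation only.

Open, from the compounds shown here alone, is how far this position tolerates other groups: a pyridin-3-yl or pyridin-2-yl would show whether the location of the ring nitrogen matters, and a phenyl carrying a methoxy, an amine or a carboxylic acid would test substitution on the terminal ring. Also open, going by these compounds, is whether the same exchange gives a step of similar direction and size on other amide-linked aryl groups or with other changes to the shared core.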